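The compounds below may be only part of what the source reports. "The series", "measured", "known", "first", "only" and "open" are said of these compounds alone.

Working notes on the series. Three compounds share one core and differ only in the substituent on the aromatic ring of carbon only. Compound 1 `CN(C)C(=O)c1cccnc1NCCCN1CCN(c2ccccc2)CC1` gives 6.31 nM in a functional assay for antagonist activity at Alpha-1A adrenergic receptor (Oryctolagus cuniculus); on this read-out higher numbers stand for weaker binding and lower numbers for tighter binding. Compound 2 `CN(C)C(=O)c1cccnc1NCCCN1CCN(c2ccccc2C#N)CC1` gives 2 nM in this assay, a modest move: a 3.2-fold lower number from compound 1 to compound 2 (0.50 log units; beyond the scatter). Compound 3 `CN(C)C(=O)c1cccnc1NCCCN1CCN(c2ccccc2OCC2CC2)CC1` gives 0.159 nM in this assay and stands at the lowest number of the three, clearly apart from both others: a 40-fold lower number from compound 1 to compound 3 (1.60 log units; beyond the scatter) and a 13-fold lower number from compound 2 to compound 3 (1.10 log units; beyond the scatter).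

Compound 4 `CCCc1ccccc1N1CCN(CCCNc2ncccc2C(=O)N(C)C)CC1` has not yet been measured. It differs from compound 3 in one place: propyl in place of cyclopropylmethoxy on an aromatic carbon. Propyl carries no oxygen, no ring and no hydrogen-bond acceptor, so compound 4 is read as lying between compound 1, which carries hydrogen at this position, and compound 3. The two large steps into compound 3 are the ones that bear on this change; part of that gain is expected to be given back when the cyclopropylmethoxy group is removed, but not all of it, since a substituent remains where compound 1 has none. The expected step is therefore a 6.3-fold higher number from compound 3 to compound 4 (0.80 log units; beyond the scatter), toward a higher number in this assay. Compound 4 is estimated at 1 nM, with a range from 0.3 nM to 4 nM.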

Compound 4, dissociation constant: 0.2 nM
Beside the measured number, compound 4's estimate is 5.0-fold (0.70 log units) above it; the measured number lies below the stated range.
By their numbers in this assay, from the lowest: compounds 3 and 4 (each within the scatter of the next); then compound 2; then compound 1.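

In this assay the exchange of cyclopropylmethoxy for propyl on this aromatic carbon leaves the number within the scatter (a 1.3-fold higher number from compound 3 to compound 4 (0.10 log units; within the scatter)), so among the compounds shown, neither the oxygen nor the three-membered ring is needed for a number in this range. Propyl, with 3 heavy atoms, no ring and 0 hydrogen-bond acceptors, also stands clearly apart from nitrile (a 10-fold lower number from compound 2 to compound 4 (1.00 log units; beyond the scatter)) and from hydrogen (a 32-fold lower number from compound 1 to compound 4 (1.50 log units; beyond the scatter)), so cyclopropylmethoxy is no longer the only group shown at this position to reach this range. Nothing available here bears on what lies behind these steps, and the numbers alone do not explain them.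

Still open, as far as these compounds go, is how the number responds to chain length and to the atom attached to the aromatic carbon, as would be tested by a methyl group, a longer chain such as butyl, or a propoxy group at this position. An amine or a carboxylic acid on the end of the propyl chain would show whether this position also accepts a chain that ends in a heteroatom.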